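This account rests on a few compounds, and the source may have more. Where it says the series, first, only, none or still open, it means among the compounds named here.

Working notes on the series. Going by the values given here, the reference is compound 1 `O=C1/C(=C/c2ccccc2)CCc2ccccc21`, which in a functional assay on CCRF-CEM cells (Homo sapiens) for inhibition (a higher number here means a weaker inhibitor, a lower number a stronger inhibitor), gives 7420 nM, the lowest of the two numbers measured so far. Its nearest neighbour is compound 2 `O=C1/C(=C/c2cccc(F)c2)CCc2ccccc21`, which in this assay gives 8010 nM; the step of a 1.1-fold higher number from compound 1 to compound 2 (0.03 log units; within the scatter) stays within the scatter. Compound 3 `O=C1/C(=C/c2ccc(F)cc2)CCc2ccccc21` has not yet been measured. Its difference from compound 1: fluoro in place of hydrogen on an aromatic carbon. Among the compounds with values here, the only measured step that bears on this, a 1.1-fold higher number from compound 1 to compound 2 (0.03 log units; within the scatter), is the same exchange on the same ring and left the number essentially unchanged. For compound 3 in this assay no step beyond the scatter is therefore expected in either direction. The step expected from this reasoning is a 1.0-fold higher number from compound 1 to compound 3 (0.00 log units; within the scatter). Compound 3 is estimated at 7500 nM in this assay. The expected range for compound 3 runs from 3700 nM to 15000 nM.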

Compound 3, half-maximal inhibitory concentration: 33400 nM
Estimate against measurement, compound 3: 4.5-fold (0.65 log units) below; the whole stated range lies below it.
By their numbers in this assay, from the lowest: compounds 1 and 2 (each within the scatter of the next); then compound 3.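

In this assay the exchange of hydrogen for fluoro on an aromatic carbon is not neutral on this ring: para to a large group, the step is a 4.5-fold higher number from compound 1 to compound 3 (0.65 log units; beyond the scatter), whereas the same exchange elsewhere on that ring gave a 1.1-fold higher number from compound 1 to compound 2 (0.03 log units; within the scatter). The outcome of this exchange thus depends on where the fluoro sits, since compound 2 at 8010 nM and compound 3 at 33400 nM carry the same group at different places on the ring. Nothing on hand explains this difference between the two places.

The compounds shown leave open whether the higher number at this place is particular to fluoro or also comes with chloro, methoxy or an amine there. Also open, going by these compounds, is whether changes elsewhere on the shared core would depend on place in the same way.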